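Weak inhibitors and an unmeasured hydroxy analogue

The compounds below may be only part of what the source reports. "The series", "measured", "known", "first", "only" and "open" are said of these compounds alone.

Compound 1, `COCc1ncc2cnnc(SC)n12`, in a functional assay for inhibition, with Homo sapiens as the target (a higher number here means a weaker inhibitor, a lower number a stronger inhibitor), gives > 48000 nM, which is a limit of the assay.
Compound 2, `C=CCSc1nncc2cnc(COC)n12`, in this assay gives 79000 nM.
Compound 3, `COCc1ncc2cnnc(NCCN(C)C)n12`, in this assay gives > 48000 nM, which is a limit of the assay.

Compound 3 therefore stands at the edge of what this assay reports, and it shares that position with another member of the set (the limit of > 48000 nM in this assay, at which 2 of the 3 values shown sit). Among the measured steps, the one from compound 1 to compound 2 is a step that the limit leaves unreadable from compound 1 to compound 2, the one from compound 1 to compound 3 is a step that the two limits leave unreadable from compound 1 to compound 3, and the one from compound 2 to compound 3 is a step that the limit leaves unreadable from compound 2 to compound 3.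

Compound 4, `COCc1ncc2cnnc(O)n12`, differs from compound 3 in one place: hydroxy in place of (2-(dimethylamino)ethyl)amino on an aromatic carbon. Among the compounds with values here, the steps that bear on this change are those ending at compound 3, since they alter the same aromatic carbon, but neither gives a readable size. No direction can be drawn from them.

Given that, compound 4 is expected to remain weak, with an estimated step that the limit leaves unreadable from compound 3 to compound 4. The estimate for compound 4 in this assay is 60000 nM, within a range from 20000 nM to 200000 nM, and most likely reported as a limit.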

Compound 4, half-maximal inhibitory concentration: > 48000 nM
Compound 4: a limit, no number; the forecaster's own chance of this, stated with the estimate: 75%; the middle value does not contradict the limit.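

In this assay compound 4 gives > 48000 nM, which is a limit of the assay, and it joins the others at that edge: the limit of > 48000 nM in this assay, at which 3 of the 4 values shown sit.

Within the data shown here, no step to compound 4 from compound 1, compound 2 or compound 3 can be read. The compounds shown leave open how much the group on this aromatic carbon changes inhibition, or in which direction.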